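This account rests on a few compounds, and the source may have more. Where it says the series, first, only, none or still open, it means among the compounds named here.

In a functional assay on A549 cells (Homo sapiens) for inhibition, read by MTT assay, with a stated time of 72 h (on this read-out lower numbers stand for stronger inhibition and higher numbers for weaker inhibition), three compounds have been measured: compound 1 (`COc1ccc(-c2nnc(SCCCN3CCN(c4nc5ccccc5o4)CC3)o2)cc1`) gives 93500 nM, compound 2 (`Clc1ccc(-c2nnc(SCCCN3CCN(c4nc5ccccc5o4)CC3)o2)cc1`) gives 127000 nM and compound 3 (`Brc1ccc(-c2nnc(SCCCN3CCN(c4nc5ccccc5o4)CC3)o2)cc1`) gives 123000 nM. Compound 3 therefore lies within the scatter of both others, and the three cannot be ranked. Compound 4 (`c1ccc(-c2nnc(SCCCN3CCN(c4nc5ccccc5o4)CC3)o2)cc1`) differs from compound 3 by hydrogen in place of bromo on an aromatic carbon. The closest evidence comes from swaps at this same place: a 1.4-fold higher number from compound 1 to compound 2 (0.13 log units; within the scatter), a 1.3-fold higher number from compound 1 to compound 3 (0.12 log units; within the scatter) and a 1.0-fold lower number from compound 2 to compound 3 (0.01 log units; within the scatter), all within the scatter. None of them has hydrogen there, so the evidence is indirect, and no change beyond the scatter is expected in this assay. The estimated step is a 1.1-fold lower number from compound 3 to compound 4 (0.03 log units; within the scatter). The expected value for compound 4 is 115000 nM, with an estimated range of 60000 nM to 200000 nM.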

Compound 4, half-maximal inhibitory concentration: 108000 nM
Compound 4: the middle estimate sits 1.1-fold (0.03 log units) above what was measured; the range from low to high includes it.
By their numbers in this assay, from the lowest: compounds 1, 4, 3 and 2 (each within the scatter of the next).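

Hydrogen gives this position an unsubstituted reference in this assay, and the substituents do not separate from it: the steps are a 1.1-fold lower number from compound 3 to compound 4 (0.06 log units; within the scatter) and a 1.2-fold lower number from compound 2 to compound 4 (0.07 log units; within the scatter) and a 1.2-fold higher number from compound 1 to compound 4 (0.06 log units; within the scatter), all within the scatter. Bromo, chloro, methoxy and hydrogen therefore cannot be told apart at this place on the ring. Nothing available explains this result.

From the compounds shown here alone, whether an amine or a carboxylic acid on the same ring carbon would shift the number stays open. So does whether a change elsewhere in the shared core would.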